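The source may hold more compounds than are shown below. What is called first, only, known or untested is meant among the compounds shown, and "the series" means these compounds.

Measured so far:
Compound 1 `COC(=O)CCSSc1ccccc1/C=N/NC(=O)c1ccccc1` gives 2100 nM in a functional assay on A2780 cells (Homo sapiens) for antiproliferative activity, read by MTT assay, with a stated time of 72 h; on this read-out higher numbers stand for weaker inhibition and lower numbers for stronger inhibition.
Compound 2 `O=C(CCSSc1ccccc1/C=N/NC(=O)c1ccccc1)OC[C@H]1OC(O)[C@H](O)[C@@H](O)[C@@H]1O` gives 5200 nM in this assay.

Among the measured compounds shown here, compound 2 has the highest of the two numbers and is thus the weaker inhibitor of the pair; its only neighbour is compound 1, and the step of a 2.5-fold higher number from compound 1 to compound 2 (0.39 log units; beyond the scatter) separates them beyond the scatter. Compound 3 `O=C(CCSSc1ccccc1/C=N/NC(=O)c1ccccc1)OC[C@H]1OC(O)C[C@@H](O)[C@@H]1O` has not been measured. It differs from compound 2 by hydrogen in place of hydroxy on a saturated ring carbon. For the measured compounds named here, no measured step involves this kind of change: the single known step, a 2.5-fold higher number from compound 1 to compound 2 (0.39 log units; beyond the scatter), adds the whole 3,4,5,6-tetrahydroxyoxan-2-yl group rather than removing one hydroxy from it, so it gives only loose guidance. Because the step of a 2.5-fold higher number from compound 1 to compound 2 (0.39 log units; beyond the scatter) was only modest for adding the entire group, removing a single hydroxy is expected to shift the number little, a 1.2-fold lower number from compound 2 to compound 3 (0.06 log units; within the scatter), likely within the scatter. Compound 3 is therefore expected to give about 4500 nM in this assay, between 2000 nM and 10000 nM.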

Compound 3, half-maximal inhibitory concentration: 2500 nM
Beside the measured number, compound 3's estimate is 1.8-fold (0.26 log units) above it; the range from low to high includes it.
By their numbers in this assay, from the lowest: compounds 1 and 3 (each within the scatter of the next); then compound 2.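

In this assay, removing this one hydroxy from the saturated ring carbon has a measurable effect: a 2.1-fold lower number from compound 2 to compound 3 (0.32 log units; beyond the scatter), a modest step, but one beyond the scatter. The ring as a whole therefore need not raise the number, since the step of a 1.2-fold higher number from compound 1 to compound 3 (0.08 log units; within the scatter) lies within the scatter and leaves compound 1 and compound 3 indistinguishable here. Nothing measured explains why this hydroxy matters.

The compounds shown leave open whether the other hydroxy groups on the ring count as much as this one. They also leave open whether a methoxy, an amine or a fluorine on this ring carbon would give a number closer to that of compound 2 or that of compound 3.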